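This account rests on a few compounds, and the source may have more. Where it says the series, first, only, none or still open, it means among the compounds named here.

Compound 3 `CCCCCc1cc(-c2cn([C@H]3C[C@H](OC(C)=O)[C@@H](COC(C)=O)O3)c(=O)[nH]c2=O)on1` gives 98.7% in a functional assay on HCT-15 cells (Homo sapiens) for cytotoxicity, read by sulforhodamine B assay, tested at 10 uM (on this read-out higher numbers stand for more inhibition at the one concentration tested (going by the name of the read-out) and lower numbers for less inhibition), and stands second highest of the three measured compounds. Compound 2 `CC(=O)OC[C@H]1O[C@@H](n2cc(-c3cc(C)no3)c(=O)[nH]c2=O)C[C@@H]1OC(C)=O` gives 102%, a value within the scatter of compound 3, while compound 1 `O=c1[nH]c(=O)n([C@H]2C[C@H](O)[C@@H](CO)O2)cc1-c1cn(Cc2ccccc2)nn1` gives 88.3%, lower than compound 3 by a margin beyond the scatter. Compound 4 `CC(=O)OC[C@H]1O[C@@H](n2cc(-c3cc(-c4ccc(C(C)C)cc4)no3)c(=O)[nH]c2=O)C[C@@H]1OC(C)=O` has not yet been measured; it differs from compound 3 by 4-isopropylphenyl in place of pentyl on an aromatic carbon. Of the measured steps only a number 3.3 percentage points lower from compound 2 to compound 3 (within the scatter) bears on this change, and it stayed within the scatter when the group on that aromatic carbon grew. The change in compound 4 is larger, so a small decrease is expected in this assay, a number 4.7 percentage points lower from compound 3 to compound 4 (within the scatter), close to the scatter. Compound 4 is therefore estimated at 94%, between 78% and 105%.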

Compound 4, a percentage reported as inhibition, at one concentration (the size of the read-out at that concentration, not a potency): 80.9%
Compound 4: the middle estimate sits 13.1 percentage points above what was measured, and the stated range covers the measured number.
By their numbers in this assay, from the lowest: compounds 4 and 1 (each within the scatter of the next); then compounds 3 and 2 (each within the scatter of the next).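

Swapping the group on this aromatic carbon can change the result in this assay, since 4-isopropylphenyl in place of pentyl gives a number 17.8 percentage points lower from compound 3 to compound 4 (beyond the scatter) and 4-isopropylphenyl in place of methyl gives a number 21.1 percentage points lower from compound 2 to compound 4 (beyond the scatter). The chain-for-chain step, by contrast, gave only a number 3.3 percentage points lower from compound 2 to compound 3 (within the scatter), so this position responds to the aromatic group but not measurably to the longer chain. No measurement here explains the drop.

As far as these compounds go, it remains open whether the aromatic ring itself or its isopropyl group accounts for the fall, which plain phenyl could help separate. How an amine or a carboxylic acid would fare on this carbon is also unknown.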